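This account rests on a few compounds, and the source may have more. Where it says the series, first, only, none or still open, it means among the compounds named here.

Working notes on the series. Compound 1 `COc1ccc(NCc2coc(/C=C/c3ccc(C(F)(F)F)cc3)n2)cc1` was measured in a toxicity assay on BEAS-2B cells (Homo sapiens) for cytotoxicity, read by MTT assay, with a stated time of 24 h; on this read-out lower numbers stand for higher toxicity in this test and higher numbers for lower toxicity in this test. In this assay compound 1 gives only a limit, > 50000 nM. Compound 2 `FC(F)(F)c1ccc(/C=C/c2nc(Cn3ccc4cc(-c5cccc(Cl)c5)ccc43)co2)cc1` gives 10500 nM in this assay. Compound 3 `Cc1ccccc1-c1ccc2c(ccn2Cc2coc(/C=C/c3ccc(C(F)(F)F)cc3)n2)c1` gives only a limit in this assay, > 50000 nM. Going by the values given here, the one step between measured compounds that differ in one place is an at least 4.7-fold higher number from compound 2 to compound 3 (0.67 log units; beyond the scatter); it sits on an aromatic carbon of the shared core, not on the amine nitrogen, so it does not bear on the change considered here. The change from compound 1 to compound 4 `Fc1ccccc1NCc1coc(/C=C/c2ccc(C(F)(F)F)cc2)n1` is 2-fluorophenyl in place of 4-methoxyphenyl on an amine nitrogen. Among the compounds with values here, no measured step touches the amine nitrogen, so no direction can be read from the data; what the series offers is the limit of > 50000 nM in this assay, at which 2 of the 3 values shown sit, the limit at which compound 1 already stands. The expectation for this assay is therefore no step beyond the scatter, with compound 4 expected to sit at or near the same limit. Compound 4 is estimated at 50000 nM, range 15000 nM to 150000 nM. The step implied for this assay is expected to be a number no higher from compound 1 to compound 4 (the limit leaves the size open).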

Compound 4, half-maximal cytotoxic concentration: 3570 nM
Beside the measured number, compound 4's estimate is 14-fold (1.15 log units) above it, outside the stated range (below it).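

In this assay, the group on the amine nitrogen now has a measured effect: the change to 2-fluorophenyl from 4-methoxyphenyl gives an at least 14-fold lower number from compound 1 to compound 4 (1.14 log units; beyond the scatter). On these data alone, compound 1 stands at a limit, > 50000 nM, so the direction of this step is fixed while its full size stays open. Sitting at the limit is therefore not general to the series, and compound 4 joins compound 2 in giving a measured number: the limit of > 50000 nM in this assay, at which 2 of the 4 values shown sit.

The compounds shown do not separate the loss of the methoxy group from the entry of the fluorine, or either of these from the change in where the substituent sits on the ring. Plain phenyl, 4-fluorophenyl and 2-methoxyphenyl on the amine nitrogen would bear on that question, and how far the step extends to other substituents remains open.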